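The source may hold more compounds than are shown below. What is called first, only, known or untested is meant among the compounds shown, and "the series" means these compounds.

Compound 1 (`Cc1nc(SCC(=O)Nc2nc(-c3ccc(Cl)cc3)cs2)n(Nc2ccccc2)c1C`) is the reference point for this small series. Going by the values given here, in a functional assay on SNB-19 cells (Homo sapiens) for antiproliferative activity, read by sulforhodamine B assay, with a stated time of 48 h (a higher number here means that more compound is tolerated, a lower number that less compound is tolerated), compound 1 gives 61700 nM, and this is the only number reported for any of the compounds. Compound 2 (`Cc1ccc(Nn2c(SCC(=O)Nc3nc(-c4ccccc4)cs3)nc(C)c2C)cc1`) sits at the limit of > 100000 nM in this assay, at which 1 of the 2 values shown sits. In this assay compound 2 reports only a limit, > 100000 nM, not a number; compound 2 differs from compound 1 in two places at once, so its result shows only that it is tolerated up to the limit, nothing about either change on its own.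

Compound 3 (`COc1ccc(Nn2c(SCC(=O)Nc3nc(-c4ccc(Cl)cc4)cs3)nc(C)c2C)cc1`) is the next compound to be measured. The change from compound 1 to compound 3 is methoxy in place of hydrogen on an aromatic carbon. Among the compounds with values here, no measured step describes this change, so the expectation rests on compound 1 alone, with compound 2 hinting that decoration of that ring can push the value toward the limit. Compound 3 is therefore expected to show a modest step toward more compound being tolerated, a 1.5-fold higher number from compound 1 to compound 3 (0.16 log units; within the scatter), which sits close to the scatter. The estimate for compound 3 in this assay is 90000 nM, with a plausible range from 40000 nM to 200000 nM, and a real chance that only a limit is reported.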

Compound 3, concentration lethal to 50% of the cells: > 100000 nM
Compound 3: no number, only a limit; the forecaster's own chance of this, stated with the estimate: 45%; middle value at least 1.1-fold (0.04 log units) from the limit.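

In this assay, compound 3 reports only a limit, > 100000 nM, and not a number. As a single change at this position, methoxy in place of hydrogen on an aromatic carbon, para to a large group, gives an at least 1.6-fold higher number from compound 1 to compound 3 (0.20 log units; that floor lies within the scatter), so the step has only a floor, and that floor does not separate the change from the scatter. Compound 2 differs from compound 1 in two places and could say nothing about either change alone, whereas compound 3 shows that this one change, phenyl to 4-methoxyphenyl, is enough to leave the series without a number for that compound, and the limit now holds most of what is known here: the limit of > 100000 nM in this assay, at which 2 of the 3 values shown sit.

As far as these compounds go, whether methoxy truly shifts the result, and by how much, stays open, since the true value of compound 3 may lie close to that of compound 1 or far from it. From the compounds shown here alone, it is also open whether another group at this position, such as an amine, a carboxylic acid or a fluorine atom, would give a number at all, or a lower one than compound 1, at 61700 nM.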